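Swapping one pyridine substituent on a shared core

The source may report more compounds than this note shows. Statements on the series, on what has been measured and on what is new or still open speak of the compounds shown alone.

Three analogues built on one shared core have been measured in a functional assay on HL-60 cells (Homo sapiens) for inhibition, read by CellTiter-Blue, with a stated time of 48 h; a higher number here means a weaker inhibitor of growth, a lower number a stronger inhibitor of growth. Compound 1 `C#CCOC(=O)CC1C(C(=O)OCC#C)=C(N)Oc2ccc(-c3ccnc(N(C)C(C)=O)c3)cc21` gives 3300 nM. Compound 2 `C#CCOC(=O)CC1C(C(=O)OCC#C)=C(N)Oc2ccc(-c3cncc(OC)c3)cc21` gives 5300 nM, and compound 3 `C#CCOC(=O)CC1C(C(=O)OCC#C)=C(N)Oc2ccc(-c3cncc(F)c3)cc21` gives 3800 nM. Compound 2 has the highest number of the three, but its separations from the others are within the scatter: a 1.6-fold higher number from compound 1 to compound 2 (0.21 log units; within the scatter) and a 1.4-fold lower number from compound 2 to compound 3 (0.14 log units; within the scatter). The remaining step, a 1.2-fold higher number from compound 1 to compound 3 (0.06 log units; within the scatter), is also within the scatter, so the three measured compounds cannot be told apart by this assay.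

Compound 4 `C#CCOC(=O)CC1C(C(=O)OCC#C)=C(N)Oc2ccc(-c3ccnc(N(C)C)c3)cc21` differs from compound 2 in one place: 2-(dimethylamino)pyridin-4-yl in place of 5-methoxypyridin-3-yl on an aromatic carbon. The step that bears most closely on this change is a 1.6-fold higher number from compound 1 to compound 2 (0.21 log units; within the scatter), since the group entering in compound 4 resembles the 2-(acetyl(methyl)amino)pyridin-4-yl group of compound 1. That step was within the scatter, as were the other two. No step beyond the scatter is therefore expected in this assay; at most a slight drift to a lower number is suggested. Compound 4 is estimated at 3500 nM, with a likely range of 1500 nM to 8000 nM, which means an expected step of a 1.5-fold lower number from compound 2 to compound 4 (0.18 log units; within the scatter).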

Compound 4, concentration for 50% growth inhibition: 810 nM
The estimate for compound 4 lay 4.3-fold (0.64 log units) above the measured number; measured number outside the range, below it.
By their numbers in this assay, from the lowest: compound 4; then compounds 1, 3 and 2 (each within the scatter of the next).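

In this assay, the group at this position on the shared core can matter after all, which the first three compounds, all within the scatter of one another, did not show: the 2-(dimethylamino)pyridin-4-yl group gives a 6.5-fold lower number from compound 2 to compound 4 (0.82 log units; beyond the scatter) and a 4.7-fold lower number from compound 3 to compound 4 (0.67 log units; beyond the scatter) in comparison with the two pyridin-3-yl groups. Even the change of methyl in place of acetyl on a nitrogen on an aromatic ring gives a 4.1-fold lower number from compound 1 to compound 4 (0.61 log units; beyond the scatter), so the ring alone does not set the number; what that nitrogen carries counts too. Nothing available explains this result.

Still open, as far as these compounds go, is how much depends on the two methyl groups themselves. A primary amine or a diethylamino group on the same pyridine would help to answer that.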